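Varying the aryloxy terminus of a shared peptidic core

A few compounds are considered here, and "the series" means these few. Any claim that something is new, unique, unknown or untested is made for them only; others in the source may bear on it.

Three compounds share one core and differ only in the aryl group attached through the oxygen on a saturated carbon. Compound 1 `CC(C)[C@H](NC(=O)COc1cccc2ccccc12)C(=O)N[C@@H](CC(=O)O)C(=O)COc1ccc(Oc2ccccc2)cc1` gives 19000 nM in a functional assay with Homo sapiens as the target; a higher number here means a weaker inhibitor, a lower number a stronger inhibitor. Compound 2 `CC(C)[C@H](NC(=O)COc1cccc2ccccc12)C(=O)N[C@@H](CC(=O)O)C(=O)COc1ccc(Oc2ccc(C(F)(F)F)cc2)cc1` gives 24900 nM in the same assay, and compound 3 `CC(C)[C@H](NC(=O)COc1cccc2ccccc12)C(=O)N[C@@H](CC(=O)O)C(=O)COc1ccc([N+](=O)[O-])cc1` gives 22800 nM. Within this set compound 3 holds the second highest of the three numbers; its nearest neighbour is compound 2, a small gap a 1.1-fold lower number from compound 2 to compound 3 (0.04 log units; within the scatter), and its furthest is compound 1, a gap of a 1.2-fold higher number from compound 1 to compound 3 (0.08 log units; within the scatter). The step of a 1.3-fold higher number from compound 1 to compound 2 (0.12 log units; within the scatter) is likewise within the scatter, so every change made so far at this end of the molecule has left the read-out essentially unmoved.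

Compound 4 `CC(C)[C@H](NC(=O)COc1cccc2ccccc12)C(=O)N[C@@H](CC(=O)O)C(=O)COc1c(F)cc(F)cc1F` continues this theme: 2,4,6-trifluorophenyl in place of 4-nitrophenyl on an oxygen on a saturated carbon. Going by the values given here, no measured step introduces fluorine on this ring, but the three steps that do bear on the same position, each within the scatter, suggest the assay is indifferent to what sits there. He therefore expects no step beyond the scatter, a 1.0-fold lower number from compound 3 to compound 4 (0.02 log units; within the scatter), and estimates compound 4 at 22000 nM, with a likely range from 11000 nM to 45000 nM.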

Compound 4, half-maximal inhibitory concentration: 14900 nM
For compound 4 the middle estimate is 1.5-fold (0.17 log units) above the measured one, within the range that was stated.
By their numbers in this assay, from the lowest: compounds 4, 1, 3 and 2 (each within the scatter of the next).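

In this assay the exchange of the ring on the oxygen gives a 1.5-fold lower number from compound 3 to compound 4 (0.18 log units; within the scatter) and so stays within the scatter, like the three earlier steps at this position. Going by these compounds alone, what compound 4 adds is that the tolerance extends to a group of a different kind: the earlier compounds all carried nitro or phenoxy groups on the ring, whereas 2,4,6-trifluorophenyl brings only fluorine. The leaving 4-nitrophenyl counts 2 hydrogen-bond acceptors and the entering 2,4,6-trifluorophenyl counts 0, and that difference in count comes with no step beyond the scatter. No measurement at hand gives a reason for the size of this step.

It remains open whether any group on this oxygen can move the read-out beyond the scatter, since the compounds shown all carry an aromatic carbon ring there, and a ring bearing an amine or a carboxylic acid, or a plain cyclohexyl group or a longer saturated chain in place of the ring, would test this. Equally open, from the compounds shown here alone, is whether the flat response holds when other parts of the shared core are changed, since here only this one end varies.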